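The compounds below may be only part of what the source reports. "The series", "measured", "known", "first", "only" and "open" are said of these compounds alone.

Measured so far:
compound 1 `Cc1nc(S(C)(=O)=O)ccc1Oc1ncnc(OC2CCN(C(=O)OC3CCC3)CC2)c1F` — a functional assay on isolated protein for inhibition of Glucose-dependent insulinotropic receptor (Homo sapiens), read by HTRF and cAMP accumulation; a lower number here means that less compound is needed, a higher number that more compound is needed for the effect: 13.6 nM
compound 2 `Cc1nc(S(C)(=O)=O)ccc1Oc1ncnc(OC2CCN(C(=O)O[C@H](C)C(F)(F)F)CC2)c1F` — this assay: 9.2 nM

Among the measured compounds shown here, compound 1 sits at one end of the two numbers; its only neighbour is compound 2, and the step of a 1.5-fold lower number from compound 1 to compound 2 (0.17 log units; within the scatter), so the two cannot be ranked. Compound 3 `Cc1nc(S(C)(=O)=O)ccc1Oc1ncnc(OC2CCN(C(=O)C3(F)CCC3)CC2)c1F` is not yet measured. It differs from compound 1 as follows: a group of 5 heavy atoms (4 carbon, 1 fluorine; one four-membered non-aromatic ring of carbon only) in place of a group of 5 heavy atoms (4 carbon, 1 oxygen; one four-membered non-aromatic ring of carbon only), on a carbonyl carbon. For the measured compounds named here, the one measured step, a 1.5-fold lower number from compound 1 to compound 2 (0.17 log units; within the scatter), concerns a change on an oxygen next to a carbonyl group, not a replacement of that oxygen-bearing group by a carbon-bearing one, so it bears on compound 3 only loosely; it does show that altering that part of compound 1 gave no effect beyond the scatter. Compound 3 is therefore expected to land near compound 1, with a 1.1-fold higher number from compound 1 to compound 3 (0.04 log units; within the scatter) expected to stay within the scatter. For compound 3 the estimate is 15 nM, in the range 5 nM to 45 nM. Going by the values given here, the change has no close precedent; the range is kept wide.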

Compound 3, half-maximal effective concentration: 24.7 nM
For compound 3 the middle estimate is 1.6-fold (0.22 log units) below the measured one, within the range that was stated.
By their numbers in this assay, from the lowest: compounds 2, 1 and 3 (each within the scatter of the next, the first and the last beyond it).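

In this assay, placing the fluorine-bearing four-membered carbon ring on the carbonyl carbon in place of cyclobutyloxy gives a 1.8-fold higher number from compound 1 to compound 3 (0.26 log units; within the scatter), so this place accepts a group attached through carbon as well as one attached through oxygen, with no change beyond the scatter. The same replacement set against the 1-(trifluoromethyl)ethyl-bearing group gives a 2.7-fold higher number from compound 2 to compound 3 (0.43 log units; beyond the scatter), the first modest separation seen at this place, while compound 1 remains within the scatter of both neighbours. The data offered here contain nothing that accounts for this separation.

Because the step from compound 1 changes the attaching atom and adds fluorine together, the two changes cannot be separated; a plain cyclobutyl on the carbonyl carbon would address this. On these data alone, an amine at the same place also remains open in this assay.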